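Swapping Hydroxy for Amino on a Second Core

The source may hold more compounds than are shown below. What is called first, only, known or untested is meant among the compounds shown, and "the series" means these compounds.

Measured so far:
- compound 1, `COc1ccc(-c2ssc(=O)c2-c2cc(OC)c(OC)c(OC)c2)cc1O`, 460 nM
- compound 2, `COc1ccc(-c2ssc(=O)c2-c2cc(OC)c(OC)c(OC)c2)cc1N`, 60 nM
- compound 3, `COc1ccc(-c2ss/c(=N/O)c2-c2cc(OC)c(OC)c(OC)c2)cc1O`, 850 nM

These values come from a functional assay on KB cells (Homo sapiens) for antiproliferative activity, read by MTT assay, with a stated time of 72 h; a lower number here means a stronger inhibitor, a higher number a weaker inhibitor. Compound 1 and compound 2 share one core and differ by amino in place of hydroxy on an aromatic carbon; this change gave a 7.7-fold lower number from compound 1 to compound 2 (0.88 log units; beyond the scatter). Compound 3 carries another core; the difference between the two cores is not broken down here, and compound 3 sits within the scatter of compound 1. Compound 4, `COc1ccc(-c2ss/c(=N/O)c2-c2cc(OC)c(OC)c(OC)c2)cc1N`, repeats the same change on the core of compound 3: amino in place of hydroxy on an aromatic carbon. Because compound 1 to compound 2 gave a 7.7-fold lower number from compound 1 to compound 2 (0.88 log units; beyond the scatter), a similar step is expected from compound 3 to compound 4, a 7.1-fold lower number from compound 3 to compound 4 (0.85 log units; beyond the scatter), and compound 4 is estimated at 120 nM in this assay, with a range from 40 nM to 350 nM.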

Compound 4, half-maximal inhibitory concentration: 99 nM
The estimate for compound 4 lay 1.2-fold (0.08 log units) above the measured number; low and high end bracket the measured number.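

In this assay, putting amino in place of hydroxy on the core of compound 3 gave an 8.6-fold lower number from compound 3 to compound 4 (0.93 log units; beyond the scatter), a clear gain on this read-out. Set beside the earlier step, the change carried over from one core to the other at much the same size: the same change on two cores in this assay, a 7.7-fold lower number (0.88 log units; beyond the scatter) from compound 1 to compound 2 and an 8.6-fold lower number (0.93 log units; beyond the scatter) from compound 3 to compound 4, 1.1-fold (0.05 log units) apart, within the scatter of two such steps

For the compounds shown here, this is only two matched pairs on two cores in one cell assay, so it shows that the step held here, not that it would hold on any other core, and it does not explain why amino gives the lower numbers.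

The compounds shown leave open how a methylamino or an acetylamino group in place of the amino group would compare. Also open, from the compounds shown here alone, is whether the step would keep its size with an ethoxy group in place of the methoxy group.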